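Arylpiperazine swap: a bromopyridyl group replaces fluorophenyl

The compounds below may be only part of what the source reports. "The series", "measured", "known", "first", "only" and "open" are said of these compounds alone.

Measured compounds:
compound 1 `CCOc1ccccc1N1CCN(CCCCn2ncc(=O)n(C)c2=O)CC1` gives 1.8 nM
compound 2 `Cn1c(=O)cnn(CCCCN2CCN(c3c(Br)cccc3C#N)CC2)c1=O` gives 450 nM
compound 3 `Cn1c(=O)cnn(CCCCN2CCN(c3ccccc3F)CC2)c1=O` gives 9.73 nM

In an assay for displacement of a labelled ligand from Adrenergic receptor alpha-1 (Homo sapiens) (a higher number here means a weaker inhibitor, a lower number a stronger inhibitor), compound 3 stands second highest of the three, with compound 1 nearest and compound 2 furthest: the step of a 5.4-fold higher number from compound 1 to compound 3 (0.73 log units; beyond the scatter) is modest, whereas a 46-fold lower number from compound 2 to compound 3 (1.67 log units; beyond the scatter) is large. Compound 4 `Cn1c(=O)cnn(CCCCN2CCN(c3cccc(Br)n3)CC2)c1=O` differs from compound 3 by 6-bromopyridin-2-yl in place of 2-fluorophenyl on an amine nitrogen in a ring. Going by the values given here, no measured step shows this exact change; the nearest guide is a 250-fold higher number from compound 1 to compound 2 (2.40 log units; beyond the scatter), where a bromine-bearing aryl group on the same ring nitrogen brought a large loss. A weakening beyond the scatter is therefore expected, though smaller than that seen with compound 2. The expected step is a 10-fold higher number from compound 3 to compound 4 (1.01 log units; beyond the scatter), so compound 4 is estimated at 100 nM, within 20 nM to 600 nM.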

Compound 4, inhibition constant: > 10000 nM
Compound 4: a limit, no number; the forecaster's own chance of this, stated with the estimate: 3%; middle value at least 100-fold (2.00 log units) away from the limit.
By their numbers in this assay, from the lowest: compound 1; then compound 3; then compound 2. At a limit, above all of these: compound 4.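

In this assay compound 4 gives > 10000 nM, which is a limit of the assay and not a number. On the amine nitrogen in a ring, 6-bromopyridin-2-yl gives the largest loss yet seen at this position, with an at least 1000-fold higher number from compound 3 to compound 4 (3.01 log units; beyond the scatter) and an at least 5500-fold higher number from compound 1 to compound 4 (3.74 log units; beyond the scatter). It also falls beyond the other bromine-bearing group, with an at least 22-fold higher number from compound 2 to compound 4 (1.34 log units; beyond the scatter).

From the compounds shown here alone, the ring nitrogen and the bromine enter together, so which of them goes with the loss stays open. A pyridin-2-yl without bromine on the same amine nitrogen would separate the two.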